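Shifting a Fluorine on the Amide Aryl Ring

The compounds below may be only part of what the source reports. "The series", "measured", "known", "first", "only" and "open" are said of these compounds alone.

Compound 1 `O=C(Nc1ccc(Cl)c(-c2nnc3c(Cl)cccn23)c1)c1ccc(F)cc1Cl` is one of three analogues that share a core and differ only in the group attached to the carbonyl carbon. In a functional assay on MDA-MB-231 cells (Homo sapiens) for antiproliferative activity, read by MTT assay, with stated times of 72 h and 4 h (a higher number here means a weaker inhibitor, a lower number a stronger inhibitor), compound 1 gives 75000 nM. Compound 2 `O=C(Nc1ccc(Cl)c(-c2nnc3c(Cl)cccn23)c1)c1ccccn1` carries a pyridin-2-yl there and gives 92000 nM. Compound 3 `O=C(Nc1ccc(Cl)c(-c2nnc3c(Cl)cccn23)c1)c1ccon1` carries a 1,2-oxazol-3-yl, and for compound 3 this assay reports only a limit of > 100000 nM. Compound 1 and compound 2 cannot be told apart, since a 1.2-fold higher number from compound 1 to compound 2 (0.09 log units; within the scatter). The remaining steps, an at least 1.3-fold higher number from compound 1 to compound 3 (0.12 log units; that floor lies within the scatter) and an at least 1.0-fold higher number from compound 2 to compound 3 (0.03 log units; that floor lies within the scatter), also stay within the scatter, so all three compounds look alike in this assay.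

Compound 4 `O=C(Nc1ccc(Cl)c(-c2nnc3c(Cl)cccn23)c1)c1c(F)cccc1Cl` is not yet measured. 2-chloro-6-fluorophenyl in place of 2-chloro-4-fluorophenyl on a carbonyl carbon The two structures hold the same atoms joined differently. Going by the values given here, none of the measured steps bears directly on this change, as each of them swapped the whole aryl ring for a heteroaryl, and none moved beyond the scatter. No step beyond the scatter is therefore expected. For compound 4 the estimate is 75000 nM, between 35000 nM and 160000 nM. That estimate corresponds to an expected step of no change at the digits printed from compound 1 to compound 4 (within the scatter).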

Compound 4, half-maximal inhibitory concentration: > 100000 nM
Compound 4 ended at the assay's limit (the forecaster's own chance of this, stated with the estimate: 30%); middle value at least 1.3-fold (0.12 log units) away from the limit.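

In this assay compound 4 gives > 100000 nM, which is a limit and not a number. Rearranging the same atoms, with 2-chloro-6-fluorophenyl in place of 2-chloro-4-fluorophenyl, gives an at least 1.3-fold higher number from compound 1 to compound 4 (0.12 log units; that floor lies within the scatter), while the change from the pyridin-2-yl group gives an at least 1.0-fold higher number from compound 2 to compound 4 (0.03 log units; that floor lies within the scatter), so a change within the aryl ring, like the earlier swaps of the whole ring, shows no step beyond the scatter, although both of these steps are only floors. The step that links compound 3 and compound 4 cannot be read, because both sit at the same limit: the limit of > 100000 nM in this assay, at which 2 of the 4 values shown sit.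

Going by these compounds, the true size of the fluorine shift therefore stays open. Also open, on these data alone, is whether an aminomethylphenyl group or a carboxylic acid on that ring would give a clearly lower number in this assay.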